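A Hydroxynaphthyl Hydrazone Built on the Weakest Analogue

The source may report more compounds than this note shows. Statements on the series, on what has been measured and on what is new or still open speak of the compounds shown alone.

Of the compounds shown here, two of a shared core have been measured in a functional assay on MGC-803 cells (Homo sapiens) for antiproliferative activity, read by MTT assay, with a stated time of 72 h; on this read-out lower numbers stand for stronger inhibition and higher numbers for weaker inhibition. Compound 1 `CCCSc1nc(N/N=C/c2cccnc2)c2nnn(Cc3ccccc3)c2n1` gives 38100 nM in this assay, the higher of the two numbers shown. Among the measured compounds shown here, compound 2 `C/C(=N\Nc1nc(SCc2ccccc2)nc2c1nnn2Cc1ccccc1)c1ccccc1O` gives 850 nM in this assay, a markedly lower number, but the two structures differ in more than one place, so their values show only that compound 1 stands at the weak end of what has been seen so far.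

Compound 3 `CCCSc1nc(N/N=C/c2c(O)ccc3ccccc23)c2nnn(Cc3ccccc3)c2n1` is an analogue of compound 1 that has not yet been measured. For the measured compounds named here, the single change is 2-hydroxynaphthalen-1-yl in place of pyridin-3-yl on a carbon with a double bond to nitrogen. Nothing measured resolves this change on its own. Going by the values given here, with only two values known, and no single-point step between measured compounds, any expectation for compound 3 rests on the fact that compound 1 is the weakest of the pair and that the other known compound, compound 2, carries a hydroxyl-bearing aromatic group on the hydrazone and gives a far lower number.

Compound 3 is therefore expected to give a lower number than compound 1 in this assay, a step of a 6.4-fold lower number from compound 1 to compound 3 (0.80 log units; beyond the scatter), with the estimate at 6000 nM and a range from 900 nM to 30000 nM.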

Compound 3, half-maximal inhibitory concentration: 3710 nM
The estimate for compound 3 lay 1.6-fold (0.21 log units) above the measured number; the measured number falls inside the stated range.
By their numbers in this assay, from the lowest: compound 2; then compound 3; then compound 1.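

In this assay, among the compounds shown here, putting 2-hydroxynaphthalen-1-yl in place of pyridin-3-yl on a carbon with a double bond to nitrogen gives a 10-fold lower number from compound 1 to compound 3 (1.01 log units; beyond the scatter), the first change at a single place that can be read, and it shows that the number responds strongly to the group at this position. The change has several parts: one six-membered aromatic ring with 1 hetero atom leaves, 2 six-membered aromatic rings of carbon only enter, and a hydrogen-bond donor is gained, so this single step cannot divide its size among those differences. Nothing measured here explains the step.

The compounds shown leave open whether the step follows the hydroxyl or the larger ring system, a question that a plain naphthalen-1-yl group, a methoxy group in place of the hydroxyl, or a 2-hydroxyphenyl group on the same core would help to separate. They also leave open whether the step holds when the chain on sulfur is a longer one, such as hexyl.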